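Methyl for Methoxy in a Tetrazolyl Amide Series

The source may hold more compounds than are shown below. What is called first, only, known or untested is meant among the compounds shown, and "the series" means these compounds.

compound 1 `COc1cc(C(=O)Nc2nn[nH]n2)nc(-c2ccccc2OC)c1` gives 35% in a functional assay on the whole organism with Rattus norvegicus as the target, at a dose of 0.3 mg/kg by the oral route; on this read-out higher numbers stand for a stronger effect at the one dose given and lower numbers for a weaker effect
compound 2 `COc1cc(C(=O)Nc2nn[nH]n2)nc(-c2ccc(N)cc2)c1` gives 12%
compound 3 `CCc1ccc(-c2cccc(C(=O)Nc3nn[nH]n3)n2)cc1` gives 14%

Compound 2 sits below compound 1 by a number 23 percentage points lower from compound 1 to compound 2 (beyond the scatter), while compound 3 lies within the scatter of it. Compound 4 `Cc1cc(C(=O)Nc2nn[nH]n2)nc(-c2ccc(N)cc2)c1` is not yet measured and differs from compound 2 by methyl in place of methoxy on an aromatic carbon. For the measured compounds named here, no measured pair shows this change; the only step in hand, from compound 1 to compound 2, concerns the aryl group and not the methoxy, so it does not bear on it. With nothing to point either way, compound 4 is expected to stay close to compound 2, an estimated a number 1 percentage points higher from compound 2 to compound 4 (within the scatter), within the scatter. Compound 4 is therefore estimated at 13%, with a range from 0% to 30%.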

Compound 4, a percentage reported as inhibition, in the whole organism at one dose (the size of the read-out at that dose, not a potency): 54%
Beside the measured number, compound 4's estimate is 41 percentage points below it; measured number outside the range, above it.
By their numbers in this assay, from the lowest: compounds 2 and 3 (each within the scatter of the next); then compound 1; then compound 4.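

The position opposite the ring nitrogen, untouched by any earlier pair, turns out to carry a large effect: methyl in place of methoxy, with the 4-aminophenyl group held fixed, gives a number 42 percentage points higher from compound 2 to compound 4 (beyond the scatter) in this assay. Nothing available explains this step.

Going by these compounds, whether the step reflects the arrival of methyl or the departure of methoxy stays open, as does how an ethyl group or a chlorine atom would read at this position. Also unresolved is whether the same change would carry over with the 2-methoxyphenyl group of compound 1.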